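The source may report more compounds than this note shows. Statements on the series, on what has been measured and on what is new or still open speak of the compounds shown alone.

Compound 1, `Oc1ccc(-c2cc(-c3ccsc3)cc(-c3ccccc3O)n2)cc1`, gives > 50000 nM. Compound 2, `Oc1ccccc1-c1cc(-c2ccoc2)cc(-c2ccccc2O)n1`, gives > 50000 nM.

Both readings come from a functional assay on HCT-15 cells (Homo sapiens) for cytotoxicity, read by CCK-8 assay; on this read-out higher numbers stand for weaker inhibition and lower numbers for stronger inhibition. For compound 2 the value in this assay is a limit of the assay, not a number. For compound 1 the value in this assay is likewise a limit. Compound 3, `Oc1ccc(-c2cc(-c3ccoc3)cc(-c3ccccc3O)n2)cc1`, differs from compound 2 by 4-hydroxyphenyl in place of 2-hydroxyphenyl on an aromatic carbon. Within the data shown here, no measured pair shows the effect of this change. Because compound 1, which also carries a 4-hydroxyphenyl group, sits at the limit of > 50000 nM in this assay, at which 2 of the 2 values shown sit, no step beyond the usual scatter is expected in this assay, so a step that the limit leaves unreadable from compound 2 to compound 3 is the expected step. Compound 3 is therefore expected near 80000 nM, within 30000 nM to 300000 nM, most likely reported again only as a limit.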

Compound 3, half-maximal inhibitory concentration: > 50000 nM
Compound 3 was reported as a limit; the forecaster's own chance of this, stated with the estimate: 85%; the middle value lies beyond the limit too.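

Among these compounds, the values of compound 1, compound 2 and compound 3 in this assay are all limits, and no step between them can be read. The compounds shown leave open whether 4-hydroxyphenyl in place of 2-hydroxyphenyl, or furan-3-yl in place of thiophen-3-yl, changes the read-out at all.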